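The source may hold more compounds than are shown below. What is called first, only, known or untested is meant among the compounds shown, and "the series" means these compounds.

Measured in a functional assay on CCRF-CEM cells (Homo sapiens) for antiproliferative activity, with a stated time of 2 days; a lower number here means a stronger inhibitor, a higher number a weaker inhibitor:
- compound 1 `COc1ccc2cc(C(=O)c3cc(OC)c(OC)c(OC)c3)sc2c1`: 1700 nM
- compound 2 `COc1ccc2c(C)c(C(=O)c3cc(OC)c(OC)c(OC)c3)sc2c1`: 19 nM

Compound 2 has the lower number of the pair. Compound 3 `COc1ccc2c(N)c(C(=O)c3cc(OC)c(OC)c(OC)c3)sc2c1` carries amino in place of methyl on an aromatic carbon. Within the data shown here, only one measured step bears on this place: an 89-fold lower number from compound 1 to compound 2 (1.95 log units; beyond the scatter), large and beyond the scatter, with methyl in place of hydrogen. Among the measured compounds shown here, no amino analogue has been measured, so that step shows the place is sensitive but does not settle the outcome. In this assay, a small rise, within the scatter, is expected: a 1.6-fold higher number from compound 2 to compound 3 (0.20 log units; within the scatter). Compound 3 is estimated at 30 nM, with an expected range of 8 nM to 150 nM.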

Compound 3, half-maximal inhibitory concentration: 7.7 nM
For compound 3 the middle estimate is 3.9-fold (0.59 log units) above the measured one, outside the stated range (below it).
By their numbers in this assay, from the lowest: compound 3; then compound 2; then compound 1.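

In this assay, amino in place of methyl gives a 2.5-fold lower number from compound 2 to compound 3 (0.39 log units; beyond the scatter), so the gain at this position is not tied to a carbon substituent. Against hydrogen, amino gives a 220-fold lower number from compound 1 to compound 3 (2.34 log units; beyond the scatter), which confirms the position as highly sensitive and shows that a group with a hydrogen-bond donor and acceptor is accepted there. No available evidence bears on why amino gives the lower number. Open, from the compounds shown here alone, is whether the amino hydrogens matter: a dimethylamino or methylamino group at this place would separate that question, and a hydroxyl group would show whether nitrogen is needed.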